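Replacing an Acetyl Group by Pyridin-4-yl: an Expectation

This account rests on a few compounds, and the source may have more. Where it says the series, first, only, none or still open, it means among the compounds named here.

Compound 1 `CC(=O)c1ccc2c(c1)C(n1ccccc1=O)=CC(C)(C)O2` was tested in a functional assay (aorta) with Rattus norvegicus as the target (a lower number here means a less potent compound, a higher number a more potent compound, by a factor of ten per unit of this negative logarithm), where compound 1 gives 7.37. Compound 2 `CC1(C)C=C(n2ccccc2=O)c2cc(OC(=O)Nc3ccccc3F)ccc2O1` gives 5.38 in this assay; of the two measured compounds, compound 1 stands higher, and the gap to compound 2 lies beyond the usual scatter. Compound 3 `CC1(C)C=C(n2ccccc2=O)c2cc(-c3ccncc3)ccc2O1` has not yet been measured. It differs from compound 1 in one place: pyridin-4-yl in place of acetyl on an aromatic carbon. Going by the values given here, no measured pair shows this change, so its effect is unknown. The step of a number 0.57 log units lower from compound 1 to compound 3 (beyond the scatter) is expected to be a modest loss. Compound 3 is expected to give 6.8, with a likely range from 6 to 7.6.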

Compound 3, logarithm of the reciprocal of the active concentration, log(1/C): 6.68
Estimate against measurement, compound 3: 0.12 log units above; the measured number falls inside the stated range.
By their numbers in this assay, from the lowest: compound 2; then compound 3; then compound 1.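

In this assay, pyridin-4-yl in place of acetyl gives a number 0.69 log units lower from compound 1 to compound 3 (beyond the scatter). Going by these compounds alone, this is the first evidence that this aromatic carbon can carry a six-membered aromatic ring, with only a modest loss rather than a collapse, although acetyl remains ahead. Nothing measured here explains the loss. The compounds shown leave open whether the ring nitrogen of pyridin-4-yl matters, which a phenyl group at this position would test, and whether a nitrile or a longer ketone such as propanoyl would match acetyl.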